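The source may hold more compounds than are shown below. What is called first, only, known or untested is meant among the compounds shown, and "the series" means these compounds.

Measured so far:
compound 1, `O=C(CCl)Nc1cccc(Cn2nc(-c3ccc(Oc4ccccc4)cc3)cc2CO)c1`, 400 nM
compound 2, `C=CC(=O)Nc1cccc(Cn2nc(-c3ccc(Oc4ccccc4)cc3)cc2C(=O)OCC)c1`, 8600 nM

Both compounds were tested in a functional assay on Maver1 cells (Homo sapiens) for inhibition, read by luminescence and CellTiter-Glo, with a stated time of 72 h; on this read-out lower numbers stand for stronger inhibition and higher numbers for weaker inhibition. Compound 2 holds the highest of the two numbers, which on this read-out means the weaker inhibition; compound 1 sits far below it, and that gap lies beyond the usual scatter. The two compounds differ in more than one place, so the values alone do not say which part of the structure carries the gap.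

Compound 3, `CCOC(=O)c1cc(-c2ccc(Oc3ccccc3)cc2)nn1Cc1cccc(NC(=O)CCl)c1`, has not yet been measured. It keeps the ethyl ester of compound 2 and changes only the group on the amide carbonyl: chloromethyl in place of vinyl on a carbonyl carbon. Compound 1 also carries a ((chloromethyl)carbonyl)amino group, and compound 1 gives the lower number, 400 nM, but compound 1 differs elsewhere too, so that comparison is only a hint. A step downward, beyond the scatter, is expected: a 5.7-fold lower number from compound 2 to compound 3 (0.76 log units; beyond the scatter). Compound 3 is expected to give about 1500 nM, with a likely range from 400 nM to 6000 nM.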

Compound 3, half-maximal inhibitory concentration: 500 nM
The estimate for compound 3 lay 3.0-fold (0.48 log units) above the measured number; the measured number falls inside the stated range.
By their numbers in this assay, from the lowest: compounds 1 and 3 (each within the scatter of the next); then compound 2.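

In this assay, the step of a 17-fold lower number from compound 2 to compound 3 (1.24 log units; beyond the scatter) comes from chloromethyl in place of vinyl on a carbonyl carbon, with the ethyl ester and the rest of the structure unchanged, so this one group on the amide carbonyl accounts for a large difference. That also settles much of the earlier gap, since ethoxycarbonyl in place of hydroxymethyl on an aromatic carbon gives only a 1.3-fold higher number from compound 1 to compound 3 (0.10 log units; within the scatter) and the two groups cannot be told apart here when chloromethyl is present. Nothing available explains why the chloromethyl group gives the lower number.

Open, on these data alone, is how a plain methyl or a bromomethyl group on this carbonyl carbon would compare. Also open, as far as these compounds go, is whether a carboxylic acid on the aromatic carbon would read like the ester, and whether the ester and hydroxymethyl groups would match when vinyl is present.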